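From phenyl to butyl on a shared core

A few compounds are considered here, and "the series" means these few. Any claim that something is new, unique, unknown or untested is made for them only; others in the source may bear on it.

- Compound 1 `O=C(NCc1cc(Cl)ccc1-n1cnnn1)[C@@H]1C[C@H]2C[C@H]2N1C(=O)[C@H](O)c1ccccc1`: 17 10^-6 cm/s
- Compound 2 `CC(C)(C)[C@@H](O)C(=O)N1CC(=O)C[C@H]1C(=O)NCc1cc(Cl)ccc1-n1cnnn1`: 0.8 10^-6 cm/s
- Compound 3 `CC(C)(C)[C@@H](O)C(=O)N1C[S+]([O-])C[C@H]1C(=O)NCc1cc(Cl)ccc1-n1cnnn1`: 0.15 10^-6 cm/s

These values come from an ADME assay on Caco-2 cells (Homo sapiens) for permeability, read by LC-MS, in the apical to basolateral direction, with a stated time of 60 min, at pH 6.5; a higher number here means that the compound crosses the layer faster, a lower number that the compound crosses the layer more slowly. Compound 1 stands highest of the three, and the gaps down to compound 2 and compound 3 lie beyond the usual scatter. Compound 4 `CCCC[C@@H](O)C(=O)N1[C@@H]2C[C@@H]2C[C@H]1C(=O)NCc1cc(Cl)ccc1-n1cnnn1` keeps the core of compound 1 but carries butyl in place of phenyl, on a saturated chain carbon bound to a carbonyl carbon and an oxygen on a saturated carbon: butyl in place of phenyl on a saturated chain carbon bound to a carbonyl carbon and an oxygen on a saturated carbon. Among the measured compounds shown here, no measured pair shows this swap alone, so the best anchor is compound 1 at 17 10^-6 cm/s. A small downward step, within the scatter, is expected. The expected change is a 1.4-fold lower number from compound 1 to compound 4 (0.15 log units; within the scatter). For compound 4 the estimated value is 12 10^-6 cm/s, with an expected range from 4 10^-6 cm/s to 30 10^-6 cm/s.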

Compound 4, apparent permeability: 35 10^-6 cm/s
For compound 4 the middle estimate is 2.9-fold (0.46 log units) below the measured one; the whole stated range lies below it.
By their numbers in this assay, from the lowest: compound 3; then compound 2; then compound 1; then compound 4.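

At the saturated chain carbon bound to a carbonyl carbon and an oxygen on a saturated carbon, butyl in place of phenyl gives a 2.1-fold higher number from compound 1 to compound 4 (0.31 log units; beyond the scatter) in this assay. Among the compounds shown here, this is the first change seen with the core held fixed, and it shows that an aromatic ring at this place is not required for a high number. No available data explain the rise.

On these data alone, whether a longer chain or an amine at this place would raise the number further remains open. So does whether the same swap would give a similar step on the cores of compound 2 and compound 3.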